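The source may report more compounds than this note shows. Statements on the series, on what has been measured and on what is new or still open speak of the compounds shown alone.

Two compounds share the core. Compound 1 `Nc1cccc2c(-c3cccc(NC(=O)c4ccc(Cl)c(C(F)(F)F)c4)c3)ccnc12` gives 2700 nM in a functional assay on UACC-62 cells (Homo sapiens) for antiproliferative activity, read by sulforhodamine B assay, with a stated time of 48 h; on this read-out lower numbers stand for stronger inhibition and higher numbers for weaker inhibition. Compound 2 `COc1ccc(C(=O)Nc2cccc(-c3ccnc4c(NC(C)=O)cccc34)c2)cc1OC` gives 560 nM in this assay, the lower of the two numbers; its gap to compound 1 lies beyond the scatter. Compound 3 `CC(=O)Nc1cccc2c(-c3cccc(NC(=O)c4ccc5c(c4)OCCO5)c3)ccnc12` is the next step: 2,3-dihydro-1,4-benzodioxin-6-yl in place of 3,4-dimethoxyphenyl on a carbonyl carbon, a swap between two groups matched in what is counted. For the measured compounds named here, no measured pair shows this change, so only a small movement is foreseen, none beyond the scatter. The expected step is a 1.1-fold higher number from compound 2 to compound 3 (0.03 log units; within the scatter). For compound 3 the estimate is 600 nM, with a range of 250 nM to 1500 nM.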

Compound 3, half-maximal inhibitory concentration: 68 nM
Estimate against measurement, compound 3: 8.8-fold (0.95 log units) above, and the stated range ends above it.
By their numbers in this assay, from the lowest: compound 3; then compound 2; then compound 1.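

Although the heavy atoms, donors and acceptors counted on this carbonyl carbon stay the same, this assay shows an 8.2-fold lower number from compound 2 to compound 3 (0.92 log units; beyond the scatter) on 2,3-dihydro-1,4-benzodioxin-6-yl replacing 3,4-dimethoxyphenyl. For the compounds shown here, this position therefore distinguishes two groups that the counts treat as matched, a sensitivity the earlier compounds could not show. No measurement here accounts for the step.

As far as these compounds go, whether the ring itself matters remains open, and a 1,3-benzodioxol-5-yl group or a 1,4-benzodioxane with added methyl groups would test this further. Compound 1 differs from compound 2 in more than one place, so its contributions cannot be separated.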